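The source may hold more compounds than are shown below. What is called first, only, known or untested is meant among the compounds shown, and "the series" means these compounds.

Compound 1 `Cc1c(C)c2c(c(C)c1N)CC(C)(C)O2` gives 7.8 mg/kg in a functional assay on the whole organism with Mus musculus as the target (a lower number here means that less compound is needed, a higher number that more compound is needed for the effect), the lowest of the two numbers measured, while compound 2 `CC(C)=Cc1c(C)c(N)c(C)c2c1OC(C)(C)C2` gives 21.9 mg/kg, and the step of a 2.8-fold higher number from compound 1 to compound 2 (0.45 log units; beyond the scatter) is the only measured one. Compound 3 `Cc1c(C)c2c(c(C)c1N)CC(C)(CBr)O2` differs from compound 1 by bromo in place of hydrogen on a saturated chain carbon bound to a saturated ring carbon. Within the data shown here, that measured step concerns an aromatic carbon and does not bear on a change at a saturated chain carbon; no measured step does. With nothing pointing either way, the step to compound 3 is expected to stay within the scatter, at a 1.2-fold higher number from compound 1 to compound 3 (0.06 log units; within the scatter). For compound 3 the estimate is 9 mg/kg, with a range from 4 mg/kg to 22 mg/kg.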

Compound 3, dose for 50% inhibition: 16 mg/kg
Estimate against measurement, compound 3: 1.8-fold (0.25 log units) below, within the range that was stated.
By their numbers in this assay, from the lowest: compound 1; then compounds 3 and 2 (each within the scatter of the next).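

In this assay, the saturated chain carbon bound to a saturated ring carbon now has a measured step of its own: methyl to bromomethyl gives a 2.1-fold higher number from compound 1 to compound 3 (0.31 log units; beyond the scatter). The position is therefore not silent, and a change away from the aromatic carbon also raises the dose needed, though only modestly. Nothing available explains this shift.

As far as these compounds go, whether the higher number belongs to bromo itself or would also follow with chloromethyl or hydroxymethyl at this place remains open. So does the outcome of an amine on this chain.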